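A few compounds are considered here, and "the series" means these few. Any claim that something is new, unique, unknown or untested is made for them only; others in the source may bear on it.

Measured in a functional assay on MCF7 cells (Homo sapiens) for inhibition, read by CCK-8 assay, with a stated time of 48 h; a higher number here means a weaker inhibitor of growth, a lower number a stronger inhibitor of growth:
- compound 1 `Cc1ccccc1Nc1nc(NC2CCCCC2)ncc1Cl`: > 100000 nM (a limit of the assay, not a number)
- compound 2 `Cc1ccccc1Nc1nc(Nc2ccc(N3CCCCC3)cn2)ncc1Cl`: 21400 nM
- compound 3 `CN1CCN(c2ccc(Nc3ncc(Cl)c(NCc4ccc(F)cc4)n3)nc2)CC1`: 19300 nM

Compound 3 stands level with compound 2, since their two values lie within the usual scatter of each other, so neither can be ranked over the other.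

Compound 4 `Cc1cccc(Nc2nc(Nc3ccc(N4CCN(C)CC4)cn3)ncc2Cl)c1` has not yet been measured. It differs from compound 3 in one place (3-methylphenyl in place of 4-fluorobenzyl on a nitrogen on an aromatic ring), with 3-methylphenyl in place of 4-fluorobenzyl on a nitrogen on an aromatic ring.

For the measured compounds named here, no measured pair shows this exact swap, so any expectation is tentative. Compound 2 also has a methylphenyl group on the matching nitrogen and gives 21400 nM, which suggests no large change. A small move toward stronger growth inhibition, or none beyond the scatter, is expected, and the estimated change is a 1.5-fold lower number from compound 3 to compound 4 (0.17 log units; within the scatter) in this assay.

For compound 4 the expected value is 13000 nM, with an estimated range from 3500 nM to 48000 nM.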

Compound 4, concentration for 50% growth inhibition: 7160 nM
Beside the measured number, compound 4's estimate is 1.8-fold (0.26 log units) above it; the measured number falls inside the stated range.
By their numbers in this assay, from the lowest: compound 4; then compounds 3 and 2 (each within the scatter of the next). At a limit, above all of these: compound 1.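

In this assay, replacing 4-fluorobenzyl with 3-methylphenyl on this nitrogen gives a 2.7-fold lower number from compound 3 to compound 4 (0.43 log units; beyond the scatter). This is the only step among these compounds that can be read, and it shows that the group on this nitrogen can shift growth inhibition by more than the usual scatter, though only modestly. The swap changes several features at once, removing the fluorine and the benzyl group while adding a methyl group on a phenyl ring, so the step cannot be assigned to any one of them, and no measurement given here explains it.

Still open, on these data alone, is how a plain phenyl group, a phenyl ring carrying an amine or a carboxylic acid, or a longer chain in place of 3-methylphenyl would read in this assay. As far as these compounds go, it is also open whether this step would hold with a different group on the other side of the shared core.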